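The compounds below may be only part of what the source reports. "The series", "measured", "known", "first", "only" and "open" are said of these compounds alone.

Compound 1 `O=C1C=C(Nc2ccc(I)cc2)C(=O)c2c1nc1n2[C@H]2OC[C@@H](O)[C@H]2OC1` gives 2300 nM in a functional assay on ECa-109 cells for inhibition, with ECa-109 cell line (Homo sapiens) as the target, read by sulforhodamine B assay (on this read-out higher numbers stand for weaker inhibition and lower numbers for stronger inhibition), and is the only one of the three measured compounds to yield a number at all. Compound 2 `O=C1C(NCc2ccccc2)=CC(=O)c2c1nc1n2[C@H]2OC[C@@H](O)[C@H]2OC1`, which carries benzylamino on the double-bonded ring carbon, reaches only > 8000 nM in this assay, and that value is a limit rather than a number. Compound 3 `CCCN(CCC)C1=CC(=O)c2c(nc3n2[C@H]2OC[C@@H](O)[C@H]2OC3)C1=O`, which carries dipropylamino at that carbon, reaches only > 16000 nM in this assay, again a limit. Among the compounds with values here, the single one-point step among the measured compounds, a step that the two limits leave unreadable from compound 2 to compound 3, cannot be sized because compound 2 sits at the limit of > 8000 nM in this assay, at which 1 of the 3 values shown sits, and compound 3 sits at the limit of > 16000 nM in this assay, at which 1 of the 3 values shown sits. Compound 4 `O=C1C=C(N2CCCC2)C(=O)c2c1nc1n2[C@H]2OC[C@@H](O)[C@H]2OC1` has not yet been measured; it differs from compound 1 by pyrrolidin-1-yl in place of (4-iodophenyl)amino on a double-bonded ring carbon. Within the data shown here, no measured step covers this exact change, yet both compounds that replace the (4-iodophenyl)amino of compound 1 with another nitrogen group give only limits, and compound 3 in particular sits at the limit of > 16000 nM in this assay, at which 1 of the 3 values shown sits. Compound 4 is therefore expected to inhibit more weakly than compound 1, by roughly a 5.2-fold higher number from compound 1 to compound 4 (0.72 log units; beyond the scatter). Compound 4 is estimated at 12000 nM, with a plausible range from 3000 nM to 40000 nM and a real chance that this assay returns only a limit.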

Compound 4, half-maximal inhibitory concentration: > 16000 nM
Compound 4 was reported as a limit; the forecaster's own chance of this, stated with the estimate: 50%; at least 1.3-fold (0.12 log units) between middle value and limit.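

In this assay compound 4 gives > 16000 nM, which is a limit of the assay and not a number. Even so, this result supplies the first readable step at this place, since the only earlier step ran between two limits: pyrrolidin-1-yl in place of (4-iodophenyl)amino on a double-bonded ring carbon brings an at least 6.9-fold higher number from compound 1 to compound 4 (0.84 log units; beyond the scatter). Within this pair, the measurable inhibition of compound 1 does not survive the loss of (4-iodophenyl)amino, which ties that number to this group and not to the shared core alone.

From the compounds shown here alone, how large the step really is stays open, because compound 4 sits at a limit: the limit of > 16000 nM in this assay, at which 2 of the 4 values shown sit. The change also removes the iodine, the six-membered aromatic ring and the hydrogen-bond donor all at once, so the pair cannot say which of them counts, and a plain phenylamino group, a 4-chlorophenylamino group or an N-methyl-N-(4-iodophenyl)amino group on the same carbon would be needed to separate them.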